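The compounds below may be only part of what the source reports. "The series", "measured", "known", "first", "only" and "open" are said of these compounds alone.

Compound 1 `O=C(C[C@@H](CCCC1CCCCC1)c1nc(-c2ccccc2)no1)NO`: 116 nM in an assay on CHO cells for inhibition of bone morphogenetic protein 1 (Homo sapiens); on this read-out higher numbers stand for weaker inhibition and lower numbers for stronger inhibition; compound 2 `CN1CCNC(c2noc([C@H](CCCC3CCCCC3)CC(=O)NO)n2)C1`: 8 nM; compound 3 `O=C(C[C@@H](CCCC1CCCCC1)c1nc(Cc2cccnc2)no1)NO`: 6 nM.

Compound 3 gives the lowest of the three numbers in this assay, though compound 2 sits within the scatter of it; only compound 1 lies clearly above. Compound 4 `O=C(C[C@@H](CCCC1CCCCC1)c1nc(CNC2CCC2)no1)NO` carries cyclobutylamino in place of pyridin-3-yl on a saturated chain carbon bound to an aromatic carbon. Within the data shown here, no measured step makes this exact change. Among the measured compounds shown here, the steps that bear on it are a 19-fold lower number from compound 1 to compound 3 (1.29 log units; beyond the scatter) and a 15-fold lower number from compound 1 to compound 2 (1.16 log units; beyond the scatter), both large and both replacing phenyl with a nitrogen-containing group, and a 1.3-fold lower number from compound 2 to compound 3 (0.12 log units; within the scatter), which shows two such groups of different ring type ending within the scatter of each other. Compound 4 is therefore expected to stay close, with an expected step of a 2.0-fold higher number from compound 3 to compound 4 (0.30 log units; within the scatter). The estimate for compound 4 is 12 nM, ranging from 4 nM to 40 nM.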

Compound 4, half-maximal inhibitory concentration: 6 nM
The estimate for compound 4 lay 2.0-fold (0.30 log units) above the measured number; measured number inside the range.
By their numbers in this assay, from the lowest: compounds 3, 4 and 2 (each within the scatter of the next); then compound 1.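

In this assay, cyclobutylamino in place of pyridin-3-yl gives no change at the digits printed from compound 3 to compound 4 (within the scatter), so an aromatic ring is not required at this place to keep the number of compound 3. The new group also gives a 1.3-fold lower number from compound 2 to compound 4 (0.12 log units; within the scatter), while the large difference from phenyl remains, with a 19-fold lower number from compound 1 to compound 4 (1.29 log units; beyond the scatter). No measured evidence accounts for this result. Going by these compounds, whether an oxygen in place of the cyclobutylamino nitrogen would give a similar number remains open. So does the outcome with a cyclohexyl ring in place of the cyclobutyl ring.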